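The compounds below may be only part of what the source reports. "The series", "measured", "known", "first", "only" and "open" are said of these compounds alone.

In an ADME assay on Vero cells (Chlorocebus sabaeus) for cytotoxicity, read by resazurin assay, with a stated time of 72 h (on this read-out lower numbers stand for stronger inhibition and higher numbers for weaker inhibition), compound 2 `COc1ccc(C(=O)CCN2CCN(c3ccc(F)cc3)CC2)cc1` gives 55000 nM and stands lowest of the two measured numbers. Compound 1 `Cc1ccc(C(=O)CCN2CCN(c3ccc(C(F)(F)F)cc3)CC2)cc1` gives 140000 nM in the series. The gap between these two numbers lies beyond the scatter. Compound 3 `COc1ccc(C(=O)CCN2CCN(c3ccc(C(F)(F)F)cc3)CC2)cc1` carries trifluoromethyl in place of fluoro on an aromatic carbon of compound 2. Among the measured compounds shown here, no measured step shows this change alone. Compound 1 at 140000 nM also carries trifluoromethyl, which points to a modest rise in this assay rather than a fall. The estimated step of a 1.5-fold higher number from compound 2 to compound 3 (0.19 log units; within the scatter) is expected to stay within the scatter. For compound 3 the estimate is 85000 nM with an expected range of 40000 nM to 180000 nM in this assay.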

Compound 3, half-maximal inhibitory concentration: 135000 nM
Compound 3: middle estimate off by 1.6-fold (0.20 log units), on the low side; low and high end bracket the measured number.
By their numbers in this assay, from the lowest: compound 2; then compounds 3 and 1 (each within the scatter of the next).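

Trifluoromethyl in place of fluoro on an aromatic carbon, para to a large group, now has a single-change reading in this assay: it gives a 2.5-fold higher number from compound 2 to compound 3 (0.39 log units; beyond the scatter) and so moves the number beyond the scatter. With trifluoromethyl held in place, methoxy in place of methyl on an aromatic carbon gives a 1.0-fold lower number from compound 1 to compound 3 (0.02 log units; within the scatter) and so stays within the scatter. Among the compounds shown here, this single step is the only reading of the fluoro-to-trifluoromethyl change.

From the compounds shown here alone, whether chloro, a nitrile or an amine at this place would follow the same direction remains open. No measurement at hand speaks to the reason for either step.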